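Straightening a Side Chain: From Isobutyl to Butyl

The source may report more compounds than this note shows. Statements on the series, on what has been measured and on what is new or still open speak of the compounds shown alone.

Compound 1, `Nc1nc(NC2CC2)c2ncn(/C=C3/CC3(CO)CO)c2n1`: in an ADME assay on HFF cells (Homo sapiens) for cytotoxicity, with a stated time of 8 days (a higher number here means that more compound is tolerated, a lower number that less compound is tolerated), compound 1 gives > 300000 nM, which is a limit of the assay rather than a number.
Compound 2, `CC(C)CSc1nc(N)nc2c1ncn2/C=C1/CC1(CO)CO`: in this assay compound 2 gives > 300000 nM, again only a limit.
Compound 3, `CC(C)CNc1nc(N)nc2c1ncn2/C=C1/CC1(CO)CO`: in this assay compound 3 gives > 300000 nM, also a limit.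

Compound 3 therefore stands exactly where its two companions stand, at the limit of > 300000 nM in this assay, at which 3 of the 3 values shown sit, and no number separates any of them. The steps between the measured compounds, a step that the two limits leave unreadable from compound 1 to compound 2, a step that the two limits leave unreadable from compound 1 to compound 3 and a step that the two limits leave unreadable from compound 2 to compound 3, all bear on the change toward compound 4, yet each of them is unreadable in size, so they give no direction and no magnitude to carry forward.

Compound 4, `CCCCNc1nc(N)nc2c1ncn2/C=C1/CC1(CO)CO`, differs from compound 3 by propyl in place of isopropyl on a saturated chain carbon bound to a nitrogen on an aromatic ring. With every comparable step unreadable, the expectation is simply that compound 4 stays with compound 3, a step of a number no higher from compound 3 to compound 4 (the limit leaves the size open) in this assay. Compound 4 is thus estimated at 300000 nM, within 150000 nM to 600000 nM, and most likely reported once more only as a limit.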

Compound 4, half-maximal cytotoxic concentration: > 300000 nM
Compound 4: a limit, no number (the forecaster's own chance of this, stated with the estimate: 85%); the middle value lies on the limit itself.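

No new step can be read among compound 1, compound 2, compound 3 and compound 4 in this assay, as each value is a limit and not a number: the limit of > 300000 nM in this assay, at which 4 of the 4 values shown sit.

The compounds shown leave open what concentration harms these cells, and whether butyl in place of isobutyl changes it at all.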